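Chloro on the benzothiazole: notes toward compound 4

A few compounds are considered here, and "the series" means these few. Any claim that something is new, unique, unknown or untested is made for them only; others in the source may bear on it.

compound 1 `O=[N+]([O-])c1cccc(-c2nn(-c3ccccc3)cc2C(Nc2nc3ccccc3s2)c2c(O)ccc3ccccc23)c1`: 43900 nM
compound 2 `Oc1ccc2ccccc2c1C(Nc1nc2ccccc2s1)c1cn(-c2ccccc2)nc1-c1ccccc1`: 48900 nM
compound 3 `O=[N+]([O-])c1ccc(-c2nn(-c3ccccc3)cc2C(Nc2nc3ccccc3s2)c2c(O)ccc3ccccc23)cc1`: 14700 nM

In a functional assay on MCF7 cells (Homo sapiens) for antiproliferative activity, read by MTT assay, with a stated time of 48 h (on this read-out higher numbers stand for weaker inhibition and lower numbers for stronger inhibition), compound 3 holds the lowest number of the three: a 3.0-fold lower number from compound 1 to compound 3 (0.48 log units; beyond the scatter) and a 3.3-fold lower number from compound 2 to compound 3 (0.52 log units; beyond the scatter), both beyond the scatter. Compounds 1 and 2 lie within the scatter of each other, a 1.1-fold higher number from compound 1 to compound 2 (0.05 log units; within the scatter).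

Compound 4 `O=[N+]([O-])c1ccc(-c2nn(-c3ccccc3)cc2C(Nc2nc3ccc(Cl)cc3s2)c2c(O)ccc3ccccc23)cc1` differs from compound 3 by chloro in place of hydrogen on an aromatic carbon. Within the data shown here, none of the measured steps touches this part of the shared core; all three concern the nitro group on the phenyl ring. Among the measured compounds shown here, they show only that a small change can move the number beyond the scatter, as in a 3.3-fold lower number from compound 2 to compound 3 (0.52 log units; beyond the scatter), or leave it within, as in a 1.1-fold higher number from compound 1 to compound 2 (0.05 log units; within the scatter). For the measured compounds named here, with no step bearing directly on the change, compound 4 is expected to sit close to compound 3, a 1.2-fold lower number from compound 3 to compound 4 (0.09 log units; within the scatter), within the scatter in either direction. Compound 4 is estimated at 12000 nM, from 5000 nM to 35000 nM.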

Compound 4, half-maximal inhibitory concentration: 38600 nM
Compound 4: the middle estimate sits 3.2-fold (0.51 log units) below what was measured; measured number outside the range, above it.
By their numbers in this assay, from the lowest: compound 3; then compounds 4, 1 and 2 (each within the scatter of the next).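

In this assay, the change from 1,3-benzothiazol-2-yl to 6-chloro-1,3-benzothiazol-2-yl gives a 2.6-fold higher number from compound 3 to compound 4 (0.42 log units; beyond the scatter) and so weakens inhibition. Among these compounds, this position, untouched by the earlier steps, therefore responds to a single chloro atom. No measurement at hand explains the step.

Going by these compounds, whether this holds only for chloro stays open, and a fluoro, a methoxy or an amine on the same carbon would test that. Also open, on these data alone, is whether chloro moves the number similarly on the cores of compound 1 and compound 2.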